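From Anilide to Cyclohexylmethyl Amide: an Expected Cytotoxicity Outcome

The source may report more compounds than this note shows. Statements on the series, on what has been measured and on what is new or still open speak of the compounds shown alone.

Compound 1 `O=C(Nc1ccccc1)c1cccc(/C=C2\CC(=O)N(c3ccccc3)C2=O)c1` was tested in an ADME assay on HCT-116 cells (Homo sapiens) for cytotoxicity, read by MTT assay, with a stated time of 72 h; on this read-out higher numbers stand for weaker inhibition and lower numbers for stronger inhibition. In this assay compound 1 gives > 100000 nM, which is a limit of the assay rather than a number. Compound 2 `Cc1ccc(N2C(=O)C/C(=C\c3cccc(C(=O)Nc4cccc(F)c4)c3)C2=O)cc1` was examined in the same way. In this assay compound 2 gives > 100000 nM, again a limit and not a number. Compound 1 therefore stands at the limit of > 100000 nM in this assay, at which 2 of the 2 values shown sit; nothing measured here separates the two compounds. Compound 3 `O=C(NCC1CCCCC1)c1cccc(/C=C2\CC(=O)N(c3ccccc3)C2=O)c1` has not yet been measured. It differs from compound 1 in one place: cyclohexylmethyl in place of phenyl on an amide-type nitrogen. Within the data shown here, no step between measured compounds is available to gauge such a change. Because compound 1 gives > 100000 nM, a limit, the estimated step is a number no higher from compound 1 to compound 3 (the limit leaves the size open), with no shift beyond the scatter expected. Compound 3 is accordingly estimated at 100000 nM, within a range from 30000 nM to 300000 nM, and is expected most likely to be reported again only as a limit.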

Compound 3, half-maximal inhibitory concentration: > 100000 nM
Compound 3: no number, only a limit; the forecaster's own chance of this, stated with the estimate: 70%; the middle value lies on the limit itself.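

No step can be read between compound 1 and compound 3 in this assay, as each is reported only as a limit: the limit of > 100000 nM in this assay, at which 3 of the 3 values shown sit. The compounds shown leave open whether cyclohexylmethyl in place of phenyl on the amide-type nitrogen alters cytotoxicity at all.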